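The compounds below may be only part of what the source reports. "The series", "measured", "known", "first", "only" and "open" are said of these compounds alone.

Measured in a physicochemical assay for lipophilicity; on this read-out higher numbers stand for higher lipophilicity and lower numbers for lower lipophilicity:
- compound 1 `CCOC[C@H](Oc1ncnc2c1cnn2-c1ncccc1Cl)C(=O)Nc1ccccn1`: 2.1
- compound 2 `CCOC[C@H](Oc1ncnc2c1cnn2-c1ncccc1Cl)C(=O)Nc1ccc(Cl)cn1`: 3
- compound 3 `CC(C)OC[C@H](Oc1ncnc2c1cnn2-c1ncccc1Cl)C(=O)Nc1ccc(C#N)cn1`: 2.5

Of these three, compound 3, at 2.5, holds the middle place, with compound 1 lower at 2.1 and compound 2 higher at 3. The next compound to be read in this assay is compound 4 `CCOC[C@H](Oc1ncnc2c1cnn2-c1ncccc1Cl)C(=O)Nc1ccc(C#N)cn1`. It differs from compound 3 by one change: hydrogen in place of methyl on a saturated chain carbon bound to an oxygen on a saturated carbon and a saturated chain carbon. Isopropoxymethyl thus becomes ethoxymethyl, while the nitrile of compound 3 stays in place.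

Among the measured compounds shown here, the only measured step is a number 0.90 log units higher from compound 1 to compound 2 (beyond the scatter). It is a chloro in place of hydrogen on an aromatic carbon, at another place in the molecule, so it shows how far a single replacement can move this series but does not measure the present change. For the measured compounds named here, no measured pair isolates hydrogen in place of methyl on this chain. The closest guide is compound 1, which carries the same ethoxymethyl but no nitrile and reads 2.1, so a small move downward is expected, not one as large as the chloro step. The expected step is a number 0.30 log units lower from compound 3 to compound 4 (within the scatter). For compound 4 the estimated value is 2.2, with an expected range from 1.9 to 2.5.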

Compound 4, distribution coefficient: 2
Compound 4: middle estimate off by 0.20 log units, on the high side, within the range that was stated.
By their numbers in this assay, from the lowest: compounds 4 and 1 (each within the scatter of the next); then compound 3; then compound 2.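

In this assay, among the compounds shown here, the chain bound through oxygen proves to be a position that registers on this read-out: hydrogen in place of methyl, taking isopropoxymethyl to ethoxymethyl, gives a number 0.50 log units lower from compound 3 to compound 4 (beyond the scatter), the first measured step at this place. With the ethoxymethyl chain held constant, cyano in place of chloro on the aromatic carbon gives a number 1.00 log units lower from compound 2 to compound 4 (beyond the scatter), while cyano in place of hydrogen on that carbon gives a number 0.10 log units lower from compound 1 to compound 4 (within the scatter). Among these three ethoxymethyl compounds, therefore, compound 2 with its chloro stands apart from the other two, and the nitrile of compound 4 cannot be told from the hydrogen of compound 1 on this read-out. Nothing available here bears on the reason for these steps.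

For the compounds shown here, the single chain pair carries the nitrile, so it remains open whether hydrogen in place of methyl would give a step of similar size with chloro or hydrogen on the aromatic carbon. Also open, as far as these compounds go, is how a longer chain such as butoxymethyl at this place, or an amine on the aromatic carbon, would read in this assay.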